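Replacing the hydroxycarbamoyl arm with a carboxy chain

The source may report more compounds than this note shows. Statements on the series, on what has been measured and on what is new or still open speak of the compounds shown alone.

Measured in a functional assay on PC-3 cells (Homo sapiens) for antiproliferative activity, read by MTT assay, with a stated time of 72 h; a lower number here means a stronger inhibitor, a higher number a weaker inhibitor:
- compound 1 `O=C(NO)c1ccc(NCCOc2ccc3cc2COC/C=C/COCc2cccc(c2)-c2ccnc(n2)N3)cc1`: 4580 nM
- compound 2 `O=C(NO)c1cccc(NCCOc2ccc3cc2COC/C=C/COCc2cccc(c2)-c2ccnc(n2)N3)c1`: > 100000 nM (a limit of the assay)
- compound 3 `O=C(CCCCCOc1ccc2cc1COC/C=C/COCc1cccc(c1)-c1ccnc(n1)N2)NO`: 8110 nM

Among the measured compounds shown here, compound 1 carries one of only two actual numbers, and compound 3 carries the other, within the scatter of it. The next analogue is compound 4 `O=C(O)CCCCCCOc1ccc2cc1COC/C=C/COCc1cccc(c1)-c1ccnc(n1)N2`, still unmeasured. Its difference from compound 1 is 4-carboxybutyl in place of (4-(hydroxycarbamoyl)phenyl)amino on a saturated chain carbon, two bonds along the chain from an oxygen on an aromatic ring. Cut one bond further out, the same change reads ((4-(hydroxycarbamoyl)phenyl)amino)methyl to 5-carboxypentyl.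

For the measured compounds named here, two measured steps bear on this. Replacing the same portion with a chain that keeps the hydroxycarbamoyl end stayed within the scatter (a 1.8-fold higher number from compound 1 to compound 3 (0.25 log units; within the scatter)). Shifting the hydroxycarbamoyl group on the ring gave a large step (an at least 21-fold higher number from compound 1 to compound 2 (1.33 log units; beyond the scatter)). Going by the values given here, no measured step removes that group, as compound 4 does, so the chain change alone predicts little, while the shift suggests that the group matters. A rise beyond the scatter is therefore expected in this assay (a 6.6-fold higher number from compound 1 to compound 4 (0.82 log units; beyond the scatter)). The estimate for compound 4 is 30000 nM, with an expected range from 9000 nM to 100000 nM.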

Compound 4, half-maximal inhibitory concentration: 8760 nM
For compound 4 the middle estimate is 3.4-fold (0.53 log units) above the measured one, outside the stated range (below it).
By their numbers in this assay, from the lowest: compounds 1, 3 and 4 (each within the scatter of the next). At a limit, above all of these: compound 2.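

In this assay, the hydroxycarbamoyl group proves dispensable at this position, as the 4-carboxybutyl chain in place of (4-(hydroxycarbamoyl)phenyl)amino gives a 1.9-fold higher number from compound 1 to compound 4 (0.28 log units; within the scatter), and carboxymethyl in place of hydroxycarbamoyl gives a 1.1-fold higher number from compound 3 to compound 4 (0.03 log units; within the scatter). Compound 2 keeps the hydroxycarbamoyl group and is a limit of the assay, not a number: the limit of > 100000 nM in this assay, at which 1 of the 4 values shown sits.

The step that rests on this limit is large, an at least 11-fold lower number from compound 2 to compound 4 (1.05 log units; beyond the scatter), so a hydroxycarbamoyl group on the ring does not by itself set the level of a compound in this series.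

As far as these compounds go, whether a chain ending in a primary amine, a methyl ester or a plain alkyl group stays at the level of compounds 1, 3 and 4 remains open. From the compounds shown here alone, the effect of a shorter or longer chain carrying the carboxylic acid also remains open.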